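Sulfonyl substituent swap in the cyanoguanidine series

This account rests on a few compounds, and the source may have more. Where it says the series, first, only, none or still open, it means among the compounds named here.

Compound 1 `N#C/N=C(\NCc1ccc(S(=O)(=O)c2ccccc2)cc1)Nc1cccnc1` is the point of departure. In an ADME assay on microsomes from liver (Mus musculus) for metabolic stability, with a stated time of 30 min, tested at 1 uM (on this read-out higher numbers stand for a more stable compound and lower numbers for a less stable compound), compound 1 gives 14%, the lowest of the two numbers recorded so far; its nearest neighbour is compound 2 `N#C/N=C(\NCc1ccc(S(=O)(=O)c2ccccc2)cc1)Nc1ccncc1`, which in this assay gives 57%. For the measured compounds named here, the only step measured between these two is a number 43 percentage points higher from compound 1 to compound 2 (beyond the scatter), and that step touches a different part of the molecule.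

Compound 3 `N#C/N=C(\NCc1ccc(S(=O)(=O)N2CC3CCC(C2)O3)cc1)Nc1cccnc1` has not yet been measured in this assay. It differs from compound 1 in one place: a group of 8 heavy atoms (6 carbon, 1 nitrogen, 1 oxygen; one five-membered non-aromatic ring with 1 hetero atom, one six-membered non-aromatic ring with 2 hetero atoms) in place of a group of 6 heavy atoms (6 carbon; one six-membered aromatic ring of carbon only), on a sulfonyl sulfur. Going by the values given here, no measured step bears on a change at the sulfonyl sulfur, so the size and direction of the step cannot be read from compound 1 and compound 2. The expectation therefore rests on compound 1 alone, which in this assay gives 14% and leaves little room downward.

The step expected from compound 1 to compound 3 is a number 11 percentage points higher from compound 1 to compound 3 (beyond the scatter). For compound 3 the estimate in this assay is 25%, with a range from 5% to 60%.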

Compound 3, percent of the compound remaining: 5.5%
For compound 3 the middle estimate is 19.5 percentage points above the measured one; the measured number falls inside the stated range.
By their numbers in this assay, from the lowest: compounds 3 and 1 (each within the scatter of the next); then compound 2.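

In this assay, exchanging phenyl for the group of 8 heavy atoms on a sulfonyl sulfur gives a number 8.5 percentage points lower from compound 1 to compound 3 (within the scatter), so this first reading at the sulfonyl sulfur does not separate the two groups on the pyridin-3-yl compounds. For the compounds shown here, a non-aromatic group carrying a ring oxygen is therefore tolerated here without a step beyond the scatter, while the change on the amine nitrogen, a number 43 percentage points higher from compound 1 to compound 2 (beyond the scatter), remains the only step that exceeds it. Going by these compounds alone, nothing measured so far speaks to what lies behind this result.

As far as these compounds go, it remains open whether the sulfonyl exchange would read the same on the pyridin-4-yl side, where compound 2 gives 57% and a number has room to move in both directions, whereas the numbers for compound 1 and compound 3 both lie near the bottom of the scale. Also open, from the compounds shown here alone, is whether other groups on the sulfonyl sulfur, such as a morpholin-4-yl, a dimethylamino or a simple methyl, would separate from phenyl in this read-out.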